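The compounds below may be only part of what the source reports. "The series", "measured", "known", "first", "only" and "open" are said of these compounds alone.

In a functional assay on MCF7 cells (Homo sapiens) for inhibition, read by sulforhodamine B assay, with a stated time of 48 h (on this read-out higher numbers stand for weaker inhibition of growth and lower numbers for stronger inhibition of growth), compound 1 `Cc1ccc(-c2c(CNC(C)(C)C)c(C(=O)O)nn2-c2ccccc2)cc1` gives > 688000 nM, which is a limit of the assay and not a number. Compound 2 `CC(C)(C)NCc1c(C(=O)O)nn(-c2ccccc2)c1-c1ccc([N+](=O)[O-])cc1` gives > 634000 nM, which is also a limit and not a number. Compound 2 therefore has no exact place on the scale. Compound 3 `CC(C)(C)NCc1c(C(=O)O)nn(-c2ccc(Cl)cc2)c1-c1ccc([N+](=O)[O-])cc1` carries one change from compound 2, phenyl to 4-chlorophenyl: chloro in place of hydrogen on an aromatic carbon. Within the data shown here, the only measured step is a step that the two limits leave unreadable from compound 1 to compound 2. That step swaps a different group and has no readable size, so it offers no size to carry over. With nothing to suggest otherwise, no shift beyond the usual scatter is expected in this assay, and neither direction is favoured. The expected step is an at least 1.0-fold lower number from compound 2 to compound 3 (0.03 log units; that floor lies within the scatter). For compound 3 the estimated value is 580000 nM, with an expected range from 200000 nM to 900000 nM. A report of only a limit is likely again.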

Compound 3, concentration for 50% growth inhibition: 550000 nM
Compound 3: middle estimate off by 1.1-fold (0.02 log units), on the high side; measured number inside the range.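

Among these compounds, compound 3 gives this series its first exact number rather than a limit, and it offers the first look at a change on this phenyl ring. In this assay, chloro in place of hydrogen on an aromatic carbon gives an at least 1.1-fold lower number from compound 2 to compound 3 (0.06 log units; that floor lies within the scatter). That floor alone shows no real gain in growth inhibition, and the true size of the step stays unknown because compound 2 stands at a limit and not a number: the limit of > 634000 nM in this assay, at which 1 of the 3 values shown sits.

From the compounds shown here alone, whether fluoro, methoxy or an amine at the same place would shift the number beyond the usual scatter stays open. Going by these compounds, it also stays open whether chloro on the same ring of compound 1, which carries methyl where compound 2 carries nitro, would give an exact number too.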